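The source may hold more compounds than are shown below. What is called first, only, known or untested is meant among the compounds shown, and "the series" means these compounds.

Three compounds share one core and differ only in a single group on an outer six-membered aromatic ring of carbon only: compound 1 `CN(Cc1ccc(OCCCNC(=N)N)cc1)c1nc2ccc(Oc3ccccc3)cc2s1`, compound 2 `CN(Cc1ccc(OCCCNC(=N)N)cc1)c1nc2ccc(Oc3ccc(C(F)(F)F)cc3)cc2s1` and compound 3 `CN(Cc1ccc(OCCCNC(=N)N)cc1)c1nc2ccc(Oc3ccc(F)cc3)cc2s1`. In an assay on SH-SY5Y cells for inhibition of Voltage-dependent N-type calcium channel subunit alpha-1B (Homo sapiens), read by FLIPR and calcium flux, with stated times of 600 s and 300 s, in the presence of a further agent that is not named here (on this read-out lower numbers stand for stronger inhibition and higher numbers for weaker inhibition), compound 1 gives 113000 nM. In this assay compound 2 gives 185000 nM, and compound 3 gives 100000 nM. Compound 3 thus sits within the scatter of both others: the swaps gave a 1.1-fold lower number from compound 1 to compound 3 (0.05 log units; within the scatter) and a 1.9-fold lower number from compound 2 to compound 3 (0.27 log units; within the scatter), and between the other two a 1.6-fold higher number from compound 1 to compound 2 (0.21 log units; within the scatter), so no real separation is seen among the three.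

Compound 4 `CN(Cc1ccc(OCCCNC(=N)N)cc1)c1nc2ccc(Oc3ccc(C#N)cc3)cc2s1` carries the next swap at that same carbon, (cyano in place of fluoro on an aromatic carbon). Among the compounds with values here, the three measured swaps at this carbon all stayed within the scatter, and no measured compound carries cyano, so nothing in the data points to a step beyond the scatter in this assay. The step my estimate implies, a 1.2-fold higher number from compound 3 to compound 4 (0.06 log units; within the scatter), is expected to stay within the scatter. Compound 4 is therefore estimated at 115000 nM, with a range from 50000 nM to 260000 nM.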

Compound 4, half-maximal inhibitory concentration: 143000 nM
The estimate for compound 4 lay 1.2-fold (0.09 log units) below the measured number, within the range that was stated.
By their numbers in this assay, from the lowest: compounds 3, 1, 4 and 2 (each within the scatter of the next).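

Cyano, a group with a triple bond, adds a fourth kind of substituent at this carbon, and in this assay it stays within the scatter of all three earlier compounds (with a 1.4-fold higher number from compound 3 to compound 4 (0.16 log units; within the scatter), with a 1.3-fold lower number from compound 2 to compound 4 (0.11 log units; within the scatter) and with a 1.3-fold higher number from compound 1 to compound 4 (0.10 log units; within the scatter)). The change from 4-fluorophenoxy to 4-cyanophenoxy therefore separates nothing, and the four compounds cannot be told apart at this position. Nothing available explains why these swaps leave the number so little changed.

From the compounds shown here alone, all four groups sit on this one carbon of the outer ring, so it remains open whether any group there can produce a step beyond the scatter. Going by these compounds, an amine, a carboxylic acid or a longer chain such as butoxy at this carbon would answer that, and the other carbons of this ring remain open too.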